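This account rests on a few compounds, and the source may have more. Where it says the series, first, only, none or still open, it means among the compounds named here.

The shared core appears in each compound with an amide arm on an aromatic carbon. Compound 1 `O=C(NCc1ccccc1)c1cccc(/C=C2\CC(=O)N(c3ccccc3)C2=O)c1` carries a benzylamino on that carbonyl carbon. In an ADME assay on SW480 cells (Homo sapiens) for cytotoxicity, read by MTT assay, with a stated time of 72 h (a lower number here means a stronger inhibitor, a higher number a weaker inhibitor), compound 1 gives only a limit of the assay, > 100000 nM. Compound 2 `O=C(c1cccc(/C=C2\CC(=O)N(c3ccccc3)C2=O)c1)N1CCCC1` carries pyrrolidin-1-yl at the same carbonyl carbon. In this assay compound 2 likewise reaches only a limit, > 100000 nM. The step that the two limits leave unreadable from compound 1 to compound 2 cannot be read, because both values sit at the limit of > 100000 nM in this assay, at which 2 of the 2 values shown sit. Among the measured compounds shown here, compound 2 thus stands at the limit, with no number of its own, and the one other value shown is a limit as well.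

Compound 3 `CCOc1ccc(NC(=O)c2cccc(/C=C3\CC(=O)N(c4ccccc4)C3=O)c2)cc1` differs from compound 2 in one place: (4-ethoxyphenyl)amino in place of pyrrolidin-1-yl on a carbonyl carbon. For the measured compounds named here, only one measured step touches this position, and it has no readable size, so no pattern can be drawn from it. With both neighbours at the limit, the step that the limit leaves unreadable from compound 2 to compound 3 is estimated to be none beyond the scatter. Compound 3 is therefore expected to give about 150000 nM, within a range from 40000 nM to 600000 nM.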

Compound 3, half-maximal inhibitory concentration: 91500 nM
Compound 3: the middle estimate sits 1.6-fold (0.21 log units) above what was measured, within the range that was stated.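

Compound 3 alone among the three compounds gives a number of its own in this assay, so this carbonyl position now has a readable value and not only limits. The change to (4-ethoxyphenyl)amino gives an at least 1.0-fold lower number from compound 2 to compound 3 (0.03 log units; that floor lies within the scatter), and the change to 4-ethoxyphenyl on the amide-type nitrogen gives an at least 1.0-fold lower number from compound 1 to compound 3 (0.03 log units; that floor lies within the scatter). Each step is known from one side only, so the data do not show whether either change has any effect on the read-out, and the single number stands beside neighbours that give no number: the limit of > 100000 nM in this assay, at which 2 of the 3 values shown sit.

The compounds shown leave open how large these steps really are, and whether the number of compound 3 depends on the whole 4-ethoxyphenyl group or on its ethoxy part alone. They also leave open how this position would read with a carboxylic acid or an amine in place of the ethoxy group, or with a longer chain there.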